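Moving a Fluorine on the Piperazine Aryl Ring

The source may hold more compounds than are shown below. What is called first, only, known or untested is meant among the compounds shown, and "the series" means these compounds.

Compound 1, `CCCn1c(=O)[nH]c2nc(-c3ccc(S(=O)(=O)N4CCN(c5ccccc5Br)CC4)cc3)[nH]c2c1=O`: 20%
Compound 2, `CCCn1c(=O)[nH]c2nc(-c3ccc(S(=O)(=O)N4CCN(c5cccc(F)c5)CC4)cc3)[nH]c2c1=O`: 44%
Compound 3, `CCCn1c(=O)[nH]c2nc(-c3ccc(S(=O)(=O)N4CCN(c5ccccc5)CC4)cc3)[nH]c2c1=O`: 27%

Three compounds share one core and differ only in the substituent on the phenyl ring attached to the piperazine nitrogen. In an assay on CHO cells for displacement of a labelled ligand from adenosine receptor A3 (Homo sapiens), read by scintillation counting, with a stated time of 45 min, tested at 1 uM, in the presence of a further agent that is not named here (on this read-out lower numbers stand for less inhibition and higher numbers for more inhibition at the one concentration tested (going by the name of the read-out)), compound 3 gives 27%, the second highest of the three numbers. Its nearest neighbour is compound 1 with 20%, a gap within the scatter; its furthest is compound 2 with 44%.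

Compound 4, `CCCn1c(=O)[nH]c2nc(-c3ccc(S(=O)(=O)N4CCN(c5ccc(F)cc5)CC4)cc3)[nH]c2c1=O`, is not yet measured. It differs from compound 3 by fluoro in place of hydrogen on an aromatic carbon. One measured step speaks to this change directly: removing a fluoro from an aromatic carbon gave a number 17 percentage points lower from compound 2 to compound 3 (beyond the scatter), while the unrelated exchange of bromo for hydrogen gave only a number 7 percentage points higher from compound 1 to compound 3 (within the scatter). The fluoro in compound 4 sits at a different place on the ring than in compound 2, so the earlier step is a guide, not a rule.

Because compound 2 shows 44%, a modest rise of roughly a number 11 percentage points higher from compound 3 to compound 4 (beyond the scatter) is expected. Compound 4 is therefore estimated at 38%, within a range of 20% to 55%.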

Compound 4, a percentage reported as inhibition, at one concentration (the size of the read-out at that concentration, not a potency): 38%
For compound 4 middle estimate and measured number coincide at the digits printed, and the stated range covers the measured number.
By their numbers in this assay, from the lowest: compounds 1 and 3 (each within the scatter of the next); then compounds 4 and 2 (each within the scatter of the next).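

In this assay, placing a fluoro para to a large group on the phenyl ring gives a rise beyond the scatter (a number 11 percentage points higher from compound 3 to compound 4 (beyond the scatter)), so the gain seen earlier with 3-fluorophenyl is not tied to a single place on the ring. The two fluoro placements cannot be told apart in this assay (a number 6 percentage points lower from compound 2 to compound 4 (within the scatter)), while 4-fluorophenyl stands clear of 2-bromophenyl (a number 18 percentage points higher from compound 1 to compound 4 (beyond the scatter)), a separation that the unsubstituted phenyl of compound 3 did not reach against compound 1. Nothing among the data shown explains how a fluoro on this ring raises the number at either place.

Still open, going by these compounds, is whether the rise belongs to fluoro alone or would also appear with a chloro, a methoxy or a nitrile at the same place on the ring, and whether a 2-fluorophenyl would follow the other two fluoro compounds or stay with 2-bromophenyl. On these data alone, each number also comes from a single concentration: it shows the size of the effect at that concentration only, and how these compounds compare at other concentrations remains unknown.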